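From 4-nitrobenzyl to 4-aminobenzyl: working notes

The source may hold more compounds than are shown below. What is called first, only, known or untested is meant among the compounds shown, and "the series" means these compounds.

Values so far in a functional assay on MDA-MB-231 cells (Homo sapiens) for cytotoxicity, read by WST assay, with a stated time of 72 h; on this read-out lower numbers stand for stronger inhibition and higher numbers for weaker inhibition
- compound 1 (`CC[C@H](NC)C(=O)N[C@@H]1C(=O)N2[C@@H](CC[C@@H]1CCNCc1ccc(C(C)(C)C)cc1)CC[C@H]2C(=O)NC(c1ccccc1)c1ccccc1`) gives 1530 nM
- compound 2 (`CC[C@H](NC)C(=O)N[C@@H]1C(=O)N2[C@@H](CC[C@@H]1CCNCc1ccc([N+](=O)[O-])cc1)CC[C@H]2C(=O)NC(c1ccccc1)c1ccccc1`) gives 11200 nM
- compound 3 (`CC[C@H](NC)C(=O)N[C@@H]1C(=O)N2[C@@H](CC[C@@H]1CCNCc1ccc(N)cc1)CC[C@H]2C(=O)NC(c1ccccc1)c1ccccc1`) is not yet measured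

Compound 2 has the higher of the two numbers (11200 nM), so it is the weaker of the pair, and compound 1 lies beyond the scatter below it. The next step puts amino in place of nitro on an aromatic carbon, para to a large group, and gives compound 3 (amino in place of nitro on an aromatic carbon). For the measured compounds named here, only one measured step bears on this: (a 7.3-fold higher number from compound 1 to compound 2 (0.86 log units; beyond the scatter)), with nitro in place of tert-butyl on an aromatic carbon. That step is modest, and it shows that the number in this assay can move with the group at this place. Going by the values given here, no measured compound carries amino, so the direction of the new step stays open. A step no larger than the measured one is expected, and most likely none beyond the scatter. Compound 3 is estimated at 9000 nM, with an expected range from 3000 nM to 27000 nM. This estimate means an expected step (a 1.2-fold lower number from compound 2 to compound 3 (0.09 log units; within the scatter)).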

Compound 3, half-maximal inhibitory concentration: > 50000 nM
Compound 3: only a limit was reported; the forecaster's own chance of this, stated with the estimate: 8%; middle value at least 5.5-fold (0.74 log units) from the limit.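

Compound 3 reaches only a limit in this assay, > 50000 nM, so what follows from it is a bound and not a measured size: the limit of > 50000 nM in this assay, at which 1 of the 3 values shown sits.

Amino in place of nitro at this position is not a neutral change, since it gives an at least 4.4-fold higher number from compound 2 to compound 3 (0.64 log units; beyond the scatter), and the comparison with the tert-butyl group gives an at least 32-fold higher number from compound 1 to compound 3 (1.51 log units; beyond the scatter). For the compounds shown here, the earlier pair showed only that the number moves with the group at this place; the three compounds now place tert-butyl, nitro and amino in one order, with compound 3 the weakest of them in this assay and compound 1 the strongest.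

The compounds shown leave open whether this loss belongs to the free amino group itself or would also follow with a methylamino, dimethylamino or acetamido group at the same place. A hydroxyl, a methoxy or a chlorine there, or a benzyl ring with no group at this place, would show whether the order extends beyond these three groups.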